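The compounds below may be only part of what the source reports. "The series", "measured", "known", "first", "only" and "open" are said of these compounds alone.

Measured compounds:
- compound 1 `COc1cc2c(Oc3ccc(NC(=O)c4nn(-c5cccc(F)c5)c(=O)c5ccccc45)cc3F)ccnc2cc1OCCCN1CCCC1`, which in a functional assay on MKN-45 cells (Homo sapiens) for cytotoxicity, read by MTT assay, with a stated time of 72 h (a higher number here means a weaker inhibitor, a lower number a stronger inhibitor), gives 160 nM
- compound 2 `COc1cc2c(Oc3ccc(NC(=O)c4nn(-c5ccccc5Br)c(=O)c5ccccc45)cc3F)ccnc2cc1OCCCN1CCCC1`, which in this assay gives 410 nM

Of these two numbers, compound 2 holds the higher one, so on the evidence so far it is the weaker of the pair. Among the measured compounds shown here, the only step between measured compounds, a 2.6-fold higher number from compound 1 to compound 2 (0.41 log units; beyond the scatter), came from exchanging the aryl group that sits on an aromatic nitrogen of the shared core, and it moved the number modestly.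

Compound 3 `COc1cc2c(Oc3ccc(NC(=O)c4nn(-c5ccc([N+](=O)[O-])cc5)c(=O)c5ccccc45)cc3F)ccnc2cc1OCCCN1CCCC1` is not yet measured. It differs from compound 2 at that same aromatic nitrogen: 4-nitrophenyl in place of 2-bromophenyl on an aromatic nitrogen. For the measured compounds named here, no measured step shows what a 4-nitrophenyl group does at this position, so the one step that bears on the question is the exchange of aryl groups already seen, which was of modest size. A similar, modest move in this assay, in either direction, is therefore expected for compound 3, with a wide margin of uncertainty.

On that basis compound 3 is estimated at 300 nM, with a likely range from 100 nM to 900 nM, which means an expected step of a 1.4-fold lower number from compound 2 to compound 3 (0.14 log units; within the scatter).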

Compound 3, half-maximal inhibitory concentration: 1620 nM
For compound 3 the middle estimate is 5.4-fold (0.73 log units) below the measured one; the whole stated range lies below it.
By their numbers in this assay, from the lowest: compound 1; then compound 2; then compound 3.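

In this assay, the aryl group on this aromatic nitrogen proves able to shift the number further than the first pair showed: 4-nitrophenyl in place of 2-bromophenyl gives a 4.0-fold higher number from compound 2 to compound 3 (0.60 log units; beyond the scatter), and 4-nitrophenyl in place of 3-fluorophenyl gives a 10-fold higher number from compound 1 to compound 3 (1.01 log units; beyond the scatter). The position therefore does not treat all aryl groups alike, and compound 3, with its 4-nitrophenyl group, is the weakest of the three, with both of its steps beyond the usual scatter. The entering group has 2 hydrogen-bond acceptors where 2-bromophenyl has 0, but no measurement available here links that difference or any other feature of the group to the rise in the number.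

Because the three aryl groups differ both in what they carry and in where they carry it, the compounds shown cannot separate the effect of the nitro group from the effect of its place on the ring. They also leave open how a plain phenyl group, or a ring bearing an amine or a methoxy group, would read at this nitrogen.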